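This account rests on a few compounds, and the source may have more. Where it says the series, first, only, none or still open, it means among the compounds named here.

In a functional assay on the whole organism (PC-3 cells) for inhibition, with Mus musculus as the target, in a xenograft, with a stated time of 8 h, at a dose of 100 mg/kg by the oral route (a lower number here means less inhibition, a higher number more inhibition at the dose given (going by the name of the read-out)), compound 2 `COCCN1C(=O)CNc2ncc(-c3ccc(C(C)(C)O)nc3)nc21` gives 91%, the higher of two numbers shown, with compound 1 `CC(C)(O)c1ccc(-c2cnc3c(n2)N(CCC2CCOCC2)C(=O)CN3)cn1` giving 88%, a difference inside the scatter. Compound 3 `CC(C)(O)c1ccc(-c2cnc3c(n2)N(CC2CCOCC2)C(=O)CN3)cn1` carries oxan-4-yl in place of methoxymethyl on a saturated chain carbon bound to an amide-type nitrogen in a ring. Going by the values given here, the only measured step that bears on this change is the one between compound 1 and compound 2, where the read-out moved by a number 3 percentage points higher from compound 1 to compound 2 (within the scatter). Since that exchange of the same two groups left the number unchanged within the scatter, the step of a number 3 percentage points lower from compound 2 to compound 3 (within the scatter) is expected to stay within the scatter as well. Compound 3 is therefore estimated at 88%, with a range from 76% to 96%.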

Compound 3, a percentage reported as inhibition, in the whole organism at one dose (the size of the read-out at that dose, not a potency): 94%
Beside the measured number, compound 3's estimate is 6 percentage points below it; the range from low to high includes it.
By their numbers in this assay, from the lowest: compounds 1, 2 and 3 (each within the scatter of the next).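

In this assay the oxan-4-yl in place of methoxymethyl gives a number 3 percentage points higher from compound 2 to compound 3 (within the scatter) and the oxan-4-yl in place of (oxan-4-yl)methyl gives a number 6 percentage points higher from compound 1 to compound 3 (within the scatter) at this same place. Across these three compounds, neither a change in the ring-bearing chain nor an exchange of ring for open ether moves the number beyond the scatter. No evidence is available that bears on these numbers. The compounds shown leave open whether an amine, a carboxylic acid or a longer chain at this place would move the number beyond the scatter.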